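The compounds below may be only part of what the source reports. "The series", "measured", "known", "first", "only" and "open" are said of these compounds alone.

In an ADME assay on the whole organism (plasma, strain BALB/c) for pharmacokinetics, with Mus musculus as the target, at a dose of 5 mg/kg by the oral route (on this read-out higher numbers stand for higher exposure at the dose given and lower numbers for lower exposure), compound 3 (`COCCNS(=O)(=O)c1ccc(C)c(C#Cc2cc(Cl)ccc2OCC(=O)O)c1`) gives 831 ng.h/mL, and compound 1 (`CCCS(=O)(=O)c1ccc(C)c(C#Cc2cc(C#N)ccc2OCC(=O)O)c1`) gives 1370 ng.h/mL, within the usual scatter of compound 3. Compound 2 (`CCCS(=O)(=O)c1ccc(F)c(C#Cc2cc(Cl)ccc2OCC(=O)O)c1`) gives 6140 ng.h/mL, a higher number beyond the scatter from compound 3. Compound 4 (`Cc1ccc(S(C)(=O)=O)cc1C#Cc1cc(Cl)ccc1OCC(=O)O`) has methyl in place of (2-methoxyethyl)amino on a sulfonyl sulfur, (methyl in place of (2-methoxyethyl)amino on a sulfonyl sulfur). Among the compounds with values here, no measured pair isolates this change. Compound 1 and compound 2 also lack (2-methoxyethyl)amino, but they differ from compound 3 elsewhere too, so their values offer only a loose guide. A moderate rise is expected, beyond the scatter but uncertain in size, and the expected step is a 2.6-fold higher number from compound 3 to compound 4 (0.42 log units; beyond the scatter). For compound 4 the estimated exposure is 2200 ng.h/mL, with an expected range of 800 ng.h/mL to 6000 ng.h/mL.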

Compound 4, area under the concentration-time curve: 1800 ng.h/mL
Beside the measured number, compound 4's estimate is 1.2-fold (0.09 log units) above it; the range from low to high includes it.
By their numbers in this assay, from the lowest: compounds 3, 1 and 4 (each within the scatter of the next, the first and the last beyond it); then compound 2.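

Within the data shown here, replacing (2-methoxyethyl)amino with methyl on the sulfonyl sulfur gives the first direct reading of this change in this assay, with a 2.2-fold higher number from compound 3 to compound 4 (0.34 log units; beyond the scatter) as a modest rise. Among these compounds, the single pair shows that exposure at this position can improve when the larger group with its hydrogen-bond donor and acceptor leaves, but not which part of that group matters. No available measurement explains the rise. Still open, as far as these compounds go, is how a plain amino group or a cyclopropyl group on the same sulfur would compare with methyl.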